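The compounds below may be only part of what the source reports. "The series", "measured", "known", "first", "only" and "open" are said of these compounds alone.

In an ADME assay on NIH3T3 cells (Mus musculus) for cytotoxicity (on this read-out higher numbers stand for lower toxicity in this test and lower numbers for higher toxicity in this test), compound 1 `COCC#Cc1cc2ncnc(Nc3ccc(OCc4cccc(F)c4)c(Cl)c3)c2s1` gives > 50 uM, which is a limit of the assay and not a number. Compound 2 `CC(C)CC#Cc1cc2ncnc(Nc3ccc(OCc4cccc(F)c4)c(Cl)c3)c2s1` gives > 50 uM, also a limit. The whole record so far is the limit of > 50 uM in this assay, at which 2 of the 2 values shown sit. Going by the values given here, the only measured change, isopropyl in place of methoxy on a saturated chain carbon bound to a triple-bonded carbon, is a step that the two limits leave unreadable from compound 1 to compound 2, so it offers no size to carry forward.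

Compound 3 `CC(C)(C)OC(=O)N1CCC[C@H]1C#Cc1cc2ncnc(Nc3ccc(OCc4cccc(F)c4)c(Cl)c3)c2s1` carries a larger change on a triple-bonded carbon: 1-(tert-butoxycarbonyl)pyrrolidin-2-yl in place of isobutyl on a triple-bonded carbon. Among the compounds with values here, no measured step covers a group of this kind, so the forecast rests on the two limits alone. With compound 2 at the limit > 50 uM, no step beyond the scatter is expected in this assay, and another limit reading is the likeliest outcome. The expected size of the step is a number no higher from compound 2 to compound 3 (the limit leaves the size open). For compound 3 the estimated value is 50 uM, with an expected range from 20 uM to 100 uM.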

Compound 3, half-maximal toxic concentration: > 100 uM
Compound 3: only a limit was reported (the forecaster's own chance of this, stated with the estimate: 75%); at least 2.0-fold (0.30 log units) between middle value and limit.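

In this assay compound 3 gives > 100 uM, which is a limit of the assay and not a number. Going by these compounds alone, compound 1 and compound 2 also sit at limits, so no step among the three can be read. The compounds shown leave open whether the groups on the triple-bonded carbon affect this read-out at all.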